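A few compounds are considered here, and "the series" means these few. Any claim that something is new, unique, unknown or untested is made for them only; others in the source may bear on it.

Working notes on the series in a functional assay on MDA-MB-231 cells (Homo sapiens) for antiproliferative activity, read by MTT assay, with a stated time of 48 h; a higher number here means a weaker inhibitor, a lower number a stronger inhibitor. Among the compounds with values here, compound 3 `C/C(=C\CC/C(C)=C/CC[C@@H]1[C@@]2(C)CCC(=O)C(C)(C)[C@H]2CC[C@@]1(C)O)CC/C=C(\C)C(=O)OCc1cn(-c2cccc(Cl)c2)nn1` gives 103000 nM, the only true number so far. Compound 1 `C/C(=C\CC/C(C)=C/CC[C@@H]1[C@@]2(C)CCC(=O)C(C)(C)[C@H]2CC[C@@]1(C)O)CC/C=C(\C)C(=O)OCc1cn(-c2ccccc2C)nn1` gives > 150000 nM, which is a limit. Compound 2 `COc1ccc(-n2cc(COC(=O)/C(C)=C/CC/C(C)=C/CC/C(C)=C/CC[C@@H]3[C@@]4(C)CCC(=O)C(C)(C)[C@H]4CC[C@@]3(C)O)nn2)cc1` gives > 150000 nM, also a limit. Next is compound 4 `C/C(=C\CC/C(C)=C/CC[C@@H]1[C@@]2(C)CCC(=O)C(C)(C)[C@H]2CC[C@@]1(C)O)CC/C=C(\C)C(=O)OCc1cn(-c2cccc(O)c2)nn1`, with the change hydroxy in place of chloro on an aromatic carbon. The relevant aryl steps are an at least 1.4-fold lower number from compound 1 to compound 3 (0.16 log units; that floor lies within the scatter) and an at least 1.4-fold lower number from compound 2 to compound 3 (0.16 log units; that floor lies within the scatter), while a step that the two limits leave unreadable from compound 1 to compound 2 adds nothing. Both readable steps rest on (the limit of > 150000 nM in this assay, at which 2 of the 3 values shown sit), and neither tests hydroxy directly. The expected change is therefore none beyond the scatter, with the estimated step being a 1.1-fold higher number from compound 3 to compound 4 (0.03 log units; within the scatter). Compound 4 is expected at 110000 nM, within an estimated range of 50000 nM to 200000 nM.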

Compound 4, half-maximal inhibitory concentration: 139000 nM
Compound 4: middle estimate off by 1.3-fold (0.10 log units), on the low side; the measured number falls inside the stated range.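

In this assay, hydroxy in place of chloro on an aromatic carbon gives a 1.3-fold higher number from compound 3 to compound 4 (0.13 log units; within the scatter), so a hydrogen-bond donor and acceptor enter with no change beyond the scatter. Against the 4-methoxyphenyl and 2-methylphenyl compounds, the steps are an at least 1.0-fold lower number from compound 2 to compound 4 (0.03 log units; that floor lies within the scatter) and an at least 1.0-fold lower number from compound 1 to compound 4 (0.03 log units; that floor lies within the scatter), so neither separates the 3-hydroxyphenyl compound from them. Both floors rest on a limit: the limit of > 150000 nM in this assay, at which 2 of the 4 values shown sit.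

Open, as far as these compounds go, is whether an amine or a carboxylic acid on the same aromatic carbon would move the number beyond the scatter. From the compounds shown here alone, whether any group at this position does so also remains open.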